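From 4-ethylphenyl to naphthalen-1-yl on a sulfur

The compounds below may be only part of what the source reports. "The series", "measured", "known", "first", "only" and "open" are said of these compounds alone.

- compound 1 `COc1ccc(SCc2ccc(/C=C/C(=O)Nc3ccccc3N)cc2)cc1OC` gives 21.9%
- compound 2 `Cc1cc(C)cc(SCc2ccc(/C=C/C(=O)Nc3ccccc3N)cc2)c1` gives 3.39%
- compound 3 `CCc1ccc(SCc2ccc(/C=C/C(=O)Nc3ccccc3N)cc2)cc1` gives 20.9%

These values come from a functional assay on HeLa cells (Homo sapiens) for inhibition, read by CCK-8 assay, with a stated time of 72 h, tested at 8 uM; on this read-out lower numbers stand for less inhibition of growth and higher numbers for more inhibition of growth at the one concentration tested. Compound 3 sits in the upper part of this small range, as shown by a number 1 percentage points lower from compound 1 to compound 3 (within the scatter) and by a number 17.5 percentage points higher from compound 2 to compound 3 (beyond the scatter).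

Compound 4 `Nc1ccccc1NC(=O)/C=C/c1ccc(CSc2cccc3ccccc23)cc1` differs from compound 3 in one place, with naphthalen-1-yl in place of 4-ethylphenyl on a sulfur.

Within the data shown here, all the measured steps swap the group at this same place, so they are the relevant guide. Besides the two above, there is a number 18.5 percentage points lower from compound 1 to compound 2 (beyond the scatter). These swaps therefore range from no visible change to a modest one. Among the measured compounds shown here, none of the measured compounds carries naphthalen-1-yl, so the direction cannot be read from the data. A small step is expected, leaning slightly downward, and a modest drop remains possible, as a number 18.5 percentage points lower from compound 1 to compound 2 (beyond the scatter) shows. The estimated change is a number 5.9 percentage points lower from compound 3 to compound 4 (within the scatter). For compound 4 the expected value is 15%, within an estimated range from 3% to 30%.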

Compound 4, percent growth inhibition at one concentration: 22.1%
Estimate against measurement, compound 4: 7.1 percentage points below; the measured number falls inside the stated range.
By their numbers in this assay, from the lowest: compound 2; then compounds 3, 1 and 4 (each within the scatter of the next).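

In this assay, the swap to the larger naphthalen-1-yl, with 2 six-membered aromatic rings of carbon only where 4-ethylphenyl has one, gives a number 1.2 percentage points higher from compound 3 to compound 4 (within the scatter), and the swap from 3,4-dimethoxyphenyl gives a number 0.2 percentage points higher from compound 1 to compound 4 (within the scatter), so this position accepts a second aromatic ring with no visible change in growth inhibition. Among these compounds, the swap from 3,5-dimethylphenyl gives a number 18.7 percentage points higher from compound 2 to compound 4 (beyond the scatter), which leaves compound 2 as the one compound of the four that stands apart from the other three. Nothing available explains why these three groups read alike or why compound 2 differs.

Going by these compounds, whether an amine or a carboxylic acid on the aromatic ring would hold this level remains open. So does the effect of a plain longer chain on the sulfur in place of the ring.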